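The source may hold more compounds than are shown below. What is called first, only, known or untested is meant among the compounds shown, and "the series" means these compounds.

Measured compounds:
Compound 1 `N#Cc1ccc(Nc2nc(Oc3ccnc4ccccc34)nc(N3CCN(c4cccc(C(F)(F)F)c4)CC3)n2)cc1C(F)(F)F` — in a functional assay on DU-145 cells (Homo sapiens) for cytotoxicity, read by sulforhodamine B assay, with a stated time of 48 h (on this read-out lower numbers stand for stronger inhibition of growth and higher numbers for weaker inhibition of growth), compound 1 gives 74100 nM.
Compound 2 `CCN1CCN(c2nc(Nc3ccc(C#N)c(C(F)(F)F)c3)nc(Oc3ccnc4ccccc34)n2)CC1` — compound 2 reaches only a limit of this assay, > 100000 nM.
Compound 3 `COc1ccc(N2CCN(c3nc(Nc4ccc(C#N)c(C(F)(F)F)c4)nc(Oc4ccnc5ccccc45)n3)CC2)cc1` — compound 3 also reaches only a limit of this assay, > 100000 nM.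

Compound 3 thus stands at the top end of what this assay reports, a point shared by compound 2, as the limit of > 100000 nM in this assay, at which 2 of the 3 values shown sit, records. Compound 4 `CC(C)N1CCN(c2nc(Nc3ccc(C#N)c(C(F)(F)F)c3)nc(Oc3ccnc4ccccc34)n2)CC1` differs from compound 3 by one change: isopropyl in place of 4-methoxyphenyl on an amine nitrogen in a ring. The measured steps that touch the same position are an at least 1.3-fold higher number from compound 1 to compound 2 (0.13 log units; that floor lies within the scatter) and an at least 1.3-fold higher number from compound 1 to compound 3 (0.13 log units; that floor lies within the scatter); between the two groups that do not carry an aromatic ring there is only a step that the two limits leave unreadable from compound 2 to compound 3. Since compound 2 with ethyl at this nitrogen already sits at the limit, and isopropyl is the nearest analogue of ethyl among these compounds, compound 4 is expected to stay in the same region, with a step that the limit leaves unreadable from compound 3 to compound 4 amounting to no readable change. Compound 4 is therefore estimated at 150000 nM in this assay, within 60000 nM to 400000 nM, most likely reported as a limit.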

Compound 4, concentration for total growth inhibition: > 100000 nM
Compound 4 ended at the assay's limit (the forecaster's own chance of this, stated with the estimate: 75%); the middle value lies beyond the limit too.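

Isopropyl on this amine nitrogen ends in the same place as ethyl and 4-methoxyphenyl, so a third group, with no ring and far fewer heavy atoms than 4-methoxyphenyl, also gives no number in this assay: the limit of > 100000 nM in this assay, at which 3 of the 4 values shown sit. Putting isopropyl in place of 3-(trifluoromethyl)phenyl gives an at least 1.3-fold higher number from compound 1 to compound 4 (0.13 log units; that floor lies within the scatter), so this change cannot be said to weaken growth inhibition beyond the usual variation between repeats. The steps among the compounds at the limit cannot be read, and compound 1 remains the only one of the four with a measured number.

The compounds shown leave open whether any group on this nitrogen can bring the value well under the limit. A chain ending in a primary amine or a carboxylic acid, or a 3-chlorophenyl group, could test this.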